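The compounds below may be only part of what the source reports. "The series", "measured", "known", "first", "only" and "open" are said of these compounds alone.

Compound 1 `CC(C)[C@H](NC(=O)c1cc(Cl)ccc1OCCCCNC(=O)OC(C)(C)C)C(=O)Nc1ccc([N+](=O)[O-])cc1Cl` carries a tert-butoxycarbonyl group on its chain amine. In a functional assay on MDA-MB-231 cells (Homo sapiens) for inhibition, read by MTT assay, with a stated time of 72 h (a lower number here means a stronger inhibitor, a higher number a weaker inhibitor), compound 1 reaches only a limit, > 10000 nM. Compound 2 `CC(C)[C@H](NC(=O)c1cc(Cl)ccc1OCCCCN)C(=O)Nc1ccc([N+](=O)[O-])cc1Cl` bears the free amine instead, a change of hydrogen in place of tert-butoxycarbonyl on an amine nitrogen. In this assay compound 2 gives 5590 nM, so an at least 1.7-fold lower number from compound 1 to compound 2 (0.25 log units; that floor lies within the scatter). That floor is set by compound 1, which sits at the limit of > 10000 nM in this assay, at which 2 of the 3 values shown sit. Compound 3 `CC(C)(C)OC[C@@H](NC(=O)c1cc(Cl)ccc1OCCNC(=O)OC(C)(C)C)C(=O)Nc1ccc([N+](=O)[O-])cc1Cl` has a different core; how its core differs from that of compound 1 is not broken down here. In this assay compound 3 again shows only a limit, > 10000 nM. Compound 4 `CC(C)(C)OC[C@@H](NC(=O)c1cc(Cl)ccc1OCCN)C(=O)Nc1ccc([N+](=O)[O-])cc1Cl` repeats the same change on compound 3, namely (hydrogen in place of tert-butoxycarbonyl on an amine nitrogen), at the same kind of place. Resting on an at least 1.7-fold lower number from compound 1 to compound 2 (0.25 log units; that floor lies within the scatter), the expected step is an at least 1.4-fold lower number from compound 3 to compound 4 (0.15 log units; that floor lies within the scatter). For compound 4 the estimate in this assay is 7000 nM, expected between 2500 nM and 20000 nM.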

Compound 4, half-maximal inhibitory concentration: 3220 nM
The estimate for compound 4 lay 2.2-fold (0.34 log units) above the measured number, within the range that was stated.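

In this assay, replacing the tert-butoxycarbonyl group with hydrogen to leave a free amine gives an at least 3.1-fold lower number from compound 3 to compound 4 (0.49 log units; beyond the scatter). The change therefore carries over to a second core with a lower number in both pairs, and here the floor of the step lies beyond the scatter, but the sizes of the two steps cannot be compared: the same change on two cores in this assay, an at least 1.7-fold lower number (0.25 log units; that floor lies within the scatter) from compound 1 to compound 2 and an at least 3.1-fold lower number (0.49 log units; beyond the scatter) from compound 3 to compound 4; the limit leaves it open whether they differ. Two pairs do not show that the change would work on other cores, and the starting compounds give only a limit rather than an exact number: the limit of > 10000 nM in this assay, at which 2 of the 4 values shown sit.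

On these data alone, compounds 2 and 4 differ in more than one place, so the separate contributions of the chain and the core remain open. Also open, as far as these compounds go, is how a dimethylamine or an acetamide at the chain end would compare with the free amine.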